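The compounds below may be only part of what the source reports. "The series", "measured", "known", "first", "only" and "open" are said of these compounds alone.

Measured in an assay on cells for inhibition of IL15-IL15 receptor (Homo sapiens), read by AlphaScreen, with stated times of 30 min and 1 h; on this read-out lower numbers stand for stronger inhibition and higher numbers for weaker inhibition:
compound 1 `CC(C)Oc1ccc(NC(=O)CCCCCCCSc2nnc(Cc3nn(C)c(=O)c4ccccc34)n2C)cc1` gives 93000 nM
compound 2 `Cn1c(Cc2nn(C)c(=O)c3ccccc23)nnc1SCC(=O)Nc1ccc(Cl)cc1Cl` gives 9110000 nM
compound 3 `Cn1c(Cc2nn(C)c(=O)c3ccccc23)nnc1SCCCCCCCCCCC(=O)Nc1ccc(Cl)cc1Cl` gives 142000 nM

Among these three numbers compound 1 has the lowest. Its nearest neighbour is compound 3, whose number lies within the usual scatter of the number of compound 1, so no order between those two can be read. The furthest is compound 2, whose number lies far beyond the scatter from that of compound 1. Compound 2 and compound 3 differ only in the length of the chain that carries the amide, and their two values show that the short chain goes with a much higher number.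

Compound 4 `Cn1c(Cc2nn(C)c(=O)c3ccccc23)nnc1SCCCCCCCC(=O)Nc1ccc(F)cc1F` differs from compound 1 in one place: 2,4-difluorophenyl in place of 4-isopropoxyphenyl on an amide-type nitrogen. The chain is unchanged. Within the data shown here, no measured pair shows this change, so the step has to be guessed from the structural change alone: the expectation is a small step toward a somewhat higher number, likely within the scatter. Compound 4 is therefore expected to give 150000 nM, in a range from 50000 nM to 500000 nM. That estimate means an expected step of a 1.6-fold higher number from compound 1 to compound 4 (0.21 log units; within the scatter).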

Compound 4, half-maximal inhibitory concentration: 110000 nM
Beside the measured number, compound 4's estimate is 1.4-fold (0.13 log units) above it; measured number inside the range.
By their numbers in this assay, from the lowest: compounds 1, 4 and 3 (each within the scatter of the next); then compound 2.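

In this assay the change from 4-isopropoxyphenyl to 2,4-difluorophenyl on the amide-type nitrogen, with the chain unchanged, gives a 1.2-fold higher number from compound 1 to compound 4 (0.07 log units; within the scatter) and so lies within the usual scatter, and no order between the two compounds can be read. This is the only pair shown that differs solely in the aryl group on that nitrogen. It shows that the number does not readably change when the isopropoxy group leaves and two fluorines enter. No measurement shown here bears on why this is so.

Still open, going by these compounds, is whether an amine or a carboxylic acid on that phenyl ring would move the number beyond the scatter. Also open, on these data alone, is how a longer chain would behave with the 4-isopropoxyphenyl amide held in place.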